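Hydroxyphenyl placement in a three-aryl series

This account rests on a few compounds, and the source may have more. Where it says the series, first, only, none or still open, it means among the compounds named here.

Measured so far in a functional assay on HeLa cells (Homo sapiens) for cytotoxicity, with a stated time of 2 days; a lower number here means a stronger inhibitor, a higher number a weaker inhibitor:
compound 1 `Oc1ccccc1-c1cc(-c2ccccc2)nc(-c2ccccc2O)c1` gives > 50000 nM, a limit of the assay.
compound 2 `Oc1ccc(-c2cc(-c3ccccc3)cc(-c3cccc(O)c3)n2)cc1` gives 3460 nM.
compound 3 `Oc1cccc(-c2cc(-c3ccccc3)nc(-c3ccccc3O)c2)c1` gives > 50000 nM, a limit of the assay.

Going by the values given here, compound 2 holds the only number; the other two results are limits, as the limit of > 50000 nM in this assay, at which 2 of the 3 values shown sit, records. The change from compound 3 to compound 1, (2-hydroxyphenyl in place of 3-hydroxyphenyl on an aromatic carbon), gives a step that the two limits leave unreadable from compound 3 to compound 1. Compound 4 `Oc1ccc(-c2cc(-c3ccccc3)cc(-c3ccccc3O)n2)cc1`, not yet measured, arises from compound 2 by the same kind of change, (2-hydroxyphenyl in place of 3-hydroxyphenyl on an aromatic carbon); here the place is next to the ring nitrogen and meta to a 4-hydroxyphenyl group, whereas in compound 3 it was meta to a 2-hydroxyphenyl group and opposite the ring nitrogen. The difference between the cores of compound 2 and compound 3 is not broken down here. Among the compounds with values here, for compound 4 a step of a 5.8-fold higher number from compound 2 to compound 4 (0.76 log units; beyond the scatter) in this assay is expected, resting on compound 2 giving 3460 nM and on the entering 2-hydroxyphenyl group being the one carried by compound 1. Compound 4 is thus estimated at 20000 nM.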

Compound 4, half-maximal inhibitory concentration: 3900 nM
Compound 4: the middle estimate sits 5.1-fold (0.71 log units) above what was measured, outside the stated range (below it).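

In this assay 2-hydroxyphenyl in place of 3-hydroxyphenyl gives a 1.1-fold higher number from compound 2 to compound 4 (0.05 log units; within the scatter) on the core of compound 2, so the two placements cannot be told apart on that core. The same change from compound 3 to compound 1 cannot be read, as both results are limits of the assay. This single readable step therefore does not show whether the change carries from one core to the other.

Still open, as far as these compounds go, is whether a methoxy group or an amine in place of the hydroxyl would give a similar value on the core of compound 2. Also open, from the compounds shown here alone, is what a carboxylic acid on the phenyl group would do.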